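Amide tail change at a limit: compound 2 to compound 4

This account rests on a few compounds, and the source may have more. Where it says the series, first, only, none or still open, it means among the compounds named here.

Compound 2 `CN(Cc1ccccc1)C(=O)C1CCN(C(=O)c2ccc(S(C)(=O)=O)c([N+](=O)[O-])c2)CC1` sits at a limit in an assay on isolated protein for inhibition of thyroid hormone receptor alpha (Homo sapiens), read by fluorescence polarization; a higher number here means a weaker inhibitor, a lower number a stronger inhibitor: compound 2 gives > 60000 nM, which is a limit of the assay and not a number. Compound 1 `CS(=O)(=O)c1ccc(C(=O)N2CCC(C(=O)N(Cc3ccccc3)c3ccccc3)CC2)cc1[N+](=O)[O-]` is at the same limit: in this assay compound 1 gives > 60000 nM. Compound 3 `CS(=O)(=O)c1ccc(C(=O)NCC(=O)N2CCCCC2)cc1[N+](=O)[O-]` gives 44000 nM in this assay, a number rather than a limit. Within the data shown here, the only one-place step among the measured compounds, a step that the two limits leave unreadable from compound 1 to compound 2, cannot be read, since both ends sit at the limit (the limit of > 60000 nM in this assay, at which 2 of the 3 values shown sit). The series therefore holds no readable step for a change on the amide-type nitrogen.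

Compound 4 `CN1CCN(C(=O)C2CCN(C(=O)c3ccc(S(C)(=O)=O)c([N+](=O)[O-])c3)CC2)CC1` is not yet measured. It differs from compound 2 in one place: 4-methylpiperazin-1-yl in place of benzyl(methyl)amino on a carbonyl carbon. Among the measured compounds shown here, no measured step bears directly on this change; the one step on the amide-type nitrogen is unreadable, and compound 3 differs from compound 2 in more than one place, so its value gives no step. For the measured compounds named here, with compound 2 at the limit and no step of known size, the expected step of a number no higher from compound 2 to compound 4 (the limit leaves the size open) is none beyond the scatter, and compound 4 is expected most likely to report only a limit again. The estimate for compound 4 is 60000 nM, between 20000 nM and 200000 nM.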

Compound 4, half-maximal inhibitory concentration: > 60000 nM
Compound 4 gave a limit, no number; the forecaster's own chance of this, stated with the estimate: 75%; the middle value lies on the limit itself.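

Compound 2 and compound 4 both stand at a limit in this assay, so no new step can be read from this pair: the limit of > 60000 nM in this assay, at which 3 of the 4 values shown sit.

The compounds shown leave open how much the amide tail on the shared core matters; only compound 3 gives a number, and it differs from compound 2 in more than one place.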